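Fluoro for chloro in a diethoxy phenyl series

A few compounds are considered here, and "the series" means these few. Any claim that something is new, unique, unknown or untested is made for them only; others in the source may bear on it.

Measured so far in a physicochemical assay for lipophilicity, read by spectrophotometry, measured as octanol-water partition, at pH 7.4; on this read-out higher numbers stand for higher lipophilicity and lower numbers for lower lipophilicity:
compound 1 `CCOc1cc(CN2CCC(NC(=O)c3ccc(N)nc3)CC2)cc(OCC)c1-c1ccc(F)cc1` gives 3.15
compound 2 `CCOc1cc(CN2CC(NC(=O)c3cncc(C)c3)C2)cc(OCC)c1F` gives 2.44
compound 3 `CCOc1cc(CN2CCC(NC(=O)c3cncc(C)c3)CC2)cc(OCC)c1Cl` gives 3.43

Compound 3 carries the highest number of the three in this assay. The gap down to compound 1 lies within the usual scatter, so no order between those two can be claimed. The gap down to compound 2 is beyond the scatter, and compound 2 stands clearly lower than compound 3; the two differ in more than one place, so only the two values themselves can be compared.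

The next compound, compound 4 `CCOc1cc(CN2CCC(NC(=O)c3cncc(C)c3)CC2)cc(OCC)c1F`, has not yet been measured. It differs from compound 3 in a single place: fluoro in place of chloro on an aromatic carbon. Within the data shown here, no pair of measured compounds differing only in this way is available, so the size of the step has to be expected rather than read off. Among the measured compounds, compound 2 is the one that bears fluoro at this place and it gives 2.44, the lowest number of the set. On that ground a step downward from compound 3 to compound 4 in this assay is expected, of a size beyond the scatter, estimated as a number 0.58 log units lower from compound 3 to compound 4 (beyond the scatter). For compound 4 the expected value in this assay is 2.85, with a likely range from 2.5 to 3.2.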

Compound 4, distribution coefficient: 2.9
For compound 4 the middle estimate is 0.05 log units below the measured one, and the stated range covers the measured number.
By their numbers in this assay, from the lowest: compound 2; then compounds 4, 1 and 3 (each within the scatter of the next, the first and the last beyond it).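

Among these compounds, the pair of compound 3 and compound 4 gives the first single-place reading at this aromatic carbon, ortho to two ethoxy groups and para to a large group: in this assay, fluoro in place of chloro gives a number 0.53 log units lower from compound 3 to compound 4 (beyond the scatter) with the rest of the structure unchanged. The earlier compounds shown here differ from one another in more than one place, so they could not show that this exchange of one halogen for another moves the read-out by itself. Nothing available explains the size or direction of this step.

From the compounds shown here alone, the step rests on a single pair, so it remains open whether the same exchange gives a similar step on another scaffold, such as the core of compound 2. Also open, going by these compounds, is where a methyl, a methoxy or a nitrile at this same carbon would fall in this assay relative to chloro and fluoro, since the pair spans only these two halogens.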